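The source may hold more compounds than are shown below. What is called first, only, known or untested is meant among the compounds shown, and "the series" means these compounds.

Measured in a functional assay on HT-29 cells (Homo sapiens) for antiproliferative activity, read by sulforhodamine B assay, with a stated time of 48 h; a higher number here means a weaker inhibitor, a lower number a stronger inhibitor:
- compound 1 `CCCN1CCN(c2ccc(S(=O)(=O)Oc3ccc(C)cc3C)cc2)C1=O`: 26000 nM
- compound 2 `CCCN1CCN(c2ccc(S(=O)(=O)Oc3c(Cl)cc(Cl)cc3Cl)cc2)C1=O`: 56000 nM
- compound 3 `CCCN1CCN(c2ccc(S(=O)(=O)Oc3cccc(F)c3)cc2)C1=O`: 18000 nM

Two steps fix the standing of compound 3 in this assay. The series shows a 1.4-fold lower number from compound 1 to compound 3 (0.16 log units; within the scatter), so that pair cannot be ranked. It also shows a 3.1-fold lower number from compound 2 to compound 3 (0.49 log units; beyond the scatter), a modest separation.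

The unmeasured neighbour is compound 4 `CCCN1CCN(c2ccc(S(=O)(=O)Oc3ccc(F)cc3)cc2)C1=O`. Its change is 4-fluorophenyl in place of 3-fluorophenyl on an oxygen, with the same atoms joined differently.

Among the measured compounds shown here, no measured step moves a fluorine alone, so the evidence is indirect. All three steps exchange the whole group on that oxygen, and they stay modest or smaller: besides the two above, the series shows a 2.2-fold higher number from compound 1 to compound 2 (0.33 log units; beyond the scatter). Even the exchange giving a 1.4-fold lower number from compound 1 to compound 3 (0.16 log units; within the scatter) involves a larger change than the one here, so no step beyond the scatter is expected, and the data suggest no direction.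

The expected step is a 1.1-fold higher number from compound 3 to compound 4 (0.05 log units; within the scatter). For compound 4 the estimated value is 20000 nM, with an expected range from 10000 nM to 38000 nM.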

Compound 4, half-maximal inhibitory concentration: 23000 nM
The estimate for compound 4 lay 1.2-fold (0.06 log units) below the measured number; the measured number falls inside the stated range.
By their numbers in this assay, from the lowest: compounds 3, 4 and 1 (each within the scatter of the next); then compound 2.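

Moving the fluorine from 3-fluorophenyl to 4-fluorophenyl on the oxygen bound to the sulfonyl sulfur is the first change in the series that only rearranges the same atoms, and in this assay it gives a 1.3-fold higher number from compound 3 to compound 4 (0.11 log units; within the scatter) and so cannot be ranked. The new group also gives a 1.1-fold lower number from compound 1 to compound 4 (0.05 log units; within the scatter) and cannot be ranked against 2,4-dimethylphenyl, whereas a 2.4-fold lower number from compound 2 to compound 4 (0.39 log units; beyond the scatter) shows that compound 2, with 2,4,6-trichlorophenyl, stands apart from this group as it does from 3-fluorophenyl. No measurement at hand accounts for these numbers.

The compounds shown leave open whether a phenyl group carrying an amine or a carboxylic acid would separate from the fluorophenyl compounds on that oxygen. They also leave open what a chain longer than propyl on the shared core would do.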